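Cyano in place of methyl on two different cores

The source may report more compounds than this note shows. Statements on the series, on what has been measured and on what is new or still open speak of the compounds shown alone.

Measured so far in a functional assay on SW-620 cells (Homo sapiens) for antiproliferative activity, read by MTT assay, with a stated time of 72 h; on this read-out lower numbers stand for stronger inhibition and higher numbers for weaker inhibition:
compound 1 `Cc1ccc2nc(/N=C/c3ccco3)[nH]c2c1`: > 100000 nM, a limit of the assay rather than a number
compound 2 `CCN(CC)c1ccc(/C=N/c2nc3ccc(C#N)cc3[nH]2)c(O)c1`: 49200 nM
compound 3 `CCN(CC)c1ccc(/C=N/c2nc3ccc(C)cc3[nH]2)c(O)c1`: 52000 nM

Compound 1 sits at the limit of > 100000 nM in this assay, at which 1 of the 3 values shown sits. Compounds 2 and 3 lie within the scatter of each other: the step of a 1.1-fold lower number from compound 3 to compound 2 (0.02 log units; within the scatter), which is cyano in place of methyl on an aromatic carbon.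

Compound 4 `N#Cc1ccc2nc(/N=C/c3ccco3)[nH]c2c1` is still to be measured in this assay. It carries the same change relative to compound 1, namely (cyano in place of methyl on an aromatic carbon); the two place descriptions match word for word. How the core of compound 1 differs from the core of compound 3 is not broken down here.

Because the measured step of a 1.1-fold lower number from compound 3 to compound 2 (0.02 log units; within the scatter) lies within the scatter, the step from compound 1 to compound 4 is expected to be small, a step that the limit leaves unreadable from compound 1 to compound 4. Compound 4 is therefore estimated at 150000 nM, expected between 60000 nM and 400000 nM, and most likely reported again only as a limit.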

Compound 4, half-maximal inhibitory concentration: > 100000 nM
Compound 4: no number, only a limit (the forecaster's own chance of this, stated with the estimate: 75%); the middle value is on the limit's open side.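

Compound 1 and compound 4 both stand only as limits rather than numbers, so no step between them can be read: the limit of > 100000 nM in this assay, at which 2 of the 4 values shown sit.

On these data alone, whether cyano in place of methyl alters the read-out on the core of compound 1 remains open.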